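The source may report more compounds than this note shows. Statements on the series, on what has been measured and on what is new or still open speak of the compounds shown alone.

Measured compounds:
compound 1, `Cc1ccc(S(=O)(=O)N2CCCCC2C)cc1C#Cc1cc(Cl)ccc1OCC(=O)O`: in a functional assay on cells for antagonist activity at prostaglandin D2 receptor 2 (Homo sapiens), read by flow cytometry, with a stated time of 10 min (on this read-out lower numbers stand for stronger inhibition and higher numbers for weaker inhibition), compound 1 gives 310 nM
compound 2, `CS(=O)(=O)c1ccc(F)c(C#Cc2cc(Cl)ccc2OCC(=O)O)c1`: in this assay compound 2 gives 95 nM

Compound 2 holds the lower of the two numbers; compound 1 sits higher, a gap beyond the usual scatter. Compound 3, `Cc1ccc(S(C)(=O)=O)cc1C#Cc1cc(Cl)ccc1OCC(=O)O`, is not yet measured. It differs from compound 2 by methyl in place of fluoro on an aromatic carbon. For the measured compounds named here, no measured pair shows this exchange, so the expectation rests on the change being a single heavy atom for another: a small step, in either direction, probably within the scatter. Compound 3 is expected at 120 nM, between 50 nM and 300 nM. The step this estimate implies is a 1.3-fold higher number from compound 2 to compound 3 (0.10 log units; within the scatter).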

Compound 3, half-maximal inhibitory concentration: 64 nM
Compound 3: middle estimate off by 1.9-fold (0.27 log units), on the high side; measured number inside the range.
By their numbers in this assay, from the lowest: compounds 3 and 2 (each within the scatter of the next); then compound 1.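

In this assay, methyl in place of fluoro on an aromatic carbon, ortho to a large group and para to a methylsulfonyl group, gives a 1.5-fold lower number from compound 2 to compound 3 (0.17 log units; within the scatter), so the number does not separate these two groups at this position. Methyl in place of 2-methylpiperidin-1-yl on a sulfonyl sulfur gives a 4.8-fold lower number from compound 1 to compound 3 (0.69 log units; beyond the scatter), a single-place reading of that substituent that the earlier pair could not give. No measurement available accounts for either step.

As far as these compounds go, whether methoxy or nitrile on the same aromatic carbon would read alike remains open. So does the reading with dimethylamino or morpholine on the sulfonyl sulfur.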